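The compounds below may be only part of what the source reports. "The series", "measured", "known", "first", "only" and "open" are said of these compounds alone.

Compound 1 `CCN(CC)CCn1cnnc1-c1cc(Oc2ccc(NC(=O)Nc3ccccc3C(F)(F)F)cc2F)ccn1` serves as the starting point of this set. In a functional assay on HT-29 cells (Homo sapiens) for antiproliferative activity, read by MTT assay, with a stated time of 72 h (on this read-out higher numbers stand for weaker inhibition and lower numbers for stronger inhibition), compound 1 gives 3410 nM. Compound 2 `CCN(CC)CCn1cnnc1-c1cc(Oc2ccc(NC(=O)Nc3ccc(F)c(F)c3)cc2F)ccn1` differs from it only by 3,4-difluorophenyl in place of 2-(trifluoromethyl)phenyl on an amide-type nitrogen. In this assay compound 2 gives 1240 nM, which amounts to a 2.8-fold lower number from compound 1 to compound 2 (0.44 log units; beyond the scatter).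

Compound 3 `CN(C)CCCn1cnnc1-c1cc(Oc2ccc(NC(=O)Nc3ccccc3C(F)(F)F)cc2F)ccn1` keeps the 2-(trifluoromethyl)phenyl of compound 1 but changes the chain on the triazole; the two cores differ by (dimethylamino)methyl in place of diethylamino on a saturated chain carbon, two bonds along the chain from an aromatic nitrogen. In this assay compound 3 gives 3130 nM, so that a 1.1-fold lower number from compound 1 to compound 3 (0.04 log units; within the scatter).

Compound 4 `CN(C)CCCn1cnnc1-c1cc(Oc2ccc(NC(=O)Nc3ccc(F)c(F)c3)cc2F)ccn1` has not yet been tested in this assay. It stands to compound 3 as compound 2 stands to compound 1, differing by 3,4-difluorophenyl in place of 2-(trifluoromethyl)phenyl on an amide-type nitrogen; the place of the change is described in the same words in both pairs, so it is the same change on the other core. Compound 4 is therefore expected to show a 2.6-fold lower number from compound 3 to compound 4 (0.42 log units; beyond the scatter), resting on the measured 2.8-fold lower number from compound 1 to compound 2 (0.44 log units; beyond the scatter), beside which the chain change in compound 3 made little difference. Compound 4 is estimated at 1200 nM, within a range from 600 nM to 2500 nM.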

Compound 4, half-maximal inhibitory concentration: 1210 nM
Compound 4: middle estimate off by 1.0-fold (0.00 log units), on the low side; low and high end bracket the measured number.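

In this assay, 3,4-difluorophenyl in place of 2-(trifluoromethyl)phenyl on an amide-type nitrogen gave a 2.6-fold lower number from compound 3 to compound 4 (0.41 log units; beyond the scatter), and this step agrees with the one measured on the other core: the same change on two cores in this assay, a 2.8-fold lower number (0.44 log units; beyond the scatter) from compound 1 to compound 2 and a 2.6-fold lower number (0.41 log units; beyond the scatter) from compound 3 to compound 4, 1.1-fold (0.03 log units) apart, within the scatter of two such steps. The chain change also carried over, with a 1.0-fold lower number from compound 2 to compound 4 (0.01 log units; within the scatter), and on neither core did it move the number beyond the scatter: the same change on two cores in this assay, a 1.1-fold lower number (0.04 log units; within the scatter) from compound 1 to compound 3 and a 1.0-fold lower number (0.01 log units; within the scatter) from compound 2 to compound 4, 1.1-fold (0.03 log units) apart, within the scatter of two such steps. Within these four compounds, the aryl change therefore transfers between the two cores and the chain change leaves its size in place, but this rests on a single pair of aryl groups and a single pair of amine chains in one cell line, and it does not show that the agreement extends to other groups or explain why it arises.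

Going by these compounds, it remains open whether the same agreement would hold for a 4-chlorophenyl or 4-methoxyphenyl group on the amide-type nitrogen. The compounds shown also leave open what a morpholine or piperidine at the end of the chain, or a longer chain, would do.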